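Hydroxypropylamino for benzylamino on two related cores

The source may hold more compounds than are shown below. What is called first, only, known or untested is meant among the compounds shown, and "the series" means these compounds.

Compound 1 `CCCCCn1c(-c2ccco2)nc2c(NCc3ccccc3)ccnc21` is a limit in an assay on isolated protein for inhibition of high affinity 3',5'-cyclic-AMP phosphodiesterase 7A (Homo sapiens), read by cAMP accumulation, with a stated time of 20 min; a lower number here means a stronger inhibitor, a higher number a weaker inhibitor: compound 1 gives > 200000 nM, which is a limit of the assay and not a number. Compound 2 `CCCCCn1c(-c2ccco2)nc2c(NCCCO)ccnc21` carries the change 2-hydroxyethyl in place of phenyl on a saturated chain carbon bound to a nitrogen on an aromatic ring and in this assay compound 2 gives 63600 nM. The measured step is an at least 3.1-fold lower number from compound 1 to compound 2 (0.49 log units; beyond the scatter); it can only be bounded, a consequence of the limit of > 200000 nM in this assay, at which 2 of the 3 values shown sit.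

Compound 3 `CCCCCn1c(-c2ccccc2)nc2c(NCc3ccccc3)nccc21` is again a limit in this assay: compound 3 gives > 200000 nM, a limit of the assay and not a number. The difference between the core of compound 3 and the core of compound 1 is not broken down here.

Compound 4 `CCCCCn1c(-c2ccccc2)nc2c(NCCCO)nccc21` is not yet measured in this assay. It differs from compound 3 by 2-hydroxyethyl in place of phenyl on a saturated chain carbon bound to a nitrogen on an aromatic ring, the same change as that from compound 1 to compound 2, at a place described in the same words. For compound 4 the expected step is an at least 2.5-fold lower number from compound 3 to compound 4 (0.39 log units; beyond the scatter), an expectation resting on an at least 3.1-fold lower number from compound 1 to compound 2 (0.49 log units; beyond the scatter). The estimate for compound 4 in this assay is 80000 nM, expected to lie between 25000 nM and 300000 nM, with a real chance that compound 4 again returns only a limit.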

Compound 4, half-maximal inhibitory concentration: > 200000 nM
Compound 4: only a limit was reported; the forecaster's own chance of this, stated with the estimate: 45%; middle value at least 2.5-fold (0.39 log units) away from the limit.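

In this assay compound 4 gives > 200000 nM, a limit of the assay and not a number. With compound 3 also a limit, no step can be read between compound 3 and compound 4: the limit of > 200000 nM in this assay, at which 3 of the 4 values shown sit.

The compounds shown leave open whether benzylamino to (3-hydroxypropyl)amino lowers the number at all on the core of compound 3.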